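The compounds below may be only part of what the source reports. "The series", "measured", "known", "first", "only" and "open" are said of these compounds alone.

Working notes on the series. Of the compounds shown here, three sharing one core have been measured in an assay for inhibition of RAC-alpha serine/threonine-protein kinase (Homo sapiens), read by HTRF, with a stated time of 1 h; a lower number here means a stronger inhibitor, a higher number a weaker inhibitor. Compound 1 `Cn1ncc(Cl)c1-c1cc(C(=O)N[C@@H]2CN[C@H](CCn3cncn3)C[C@H]2c2ccc(Cl)c(Cl)c2)oc1Cl` gives 4.47 nM. Compound 2 `Cn1ncc(Cl)c1-c1cc(C(=O)N[C@@H]2CNCC[C@H]2c2ccc(C(F)(F)F)cc2)oc1Cl` gives 9.3 nM. Compound 3 `Cn1ncc(Cl)c1-c1cc(C(=O)N[C@@H]2CN[C@H](CC(=O)NC3CC3)C[C@H]2c2ccc(Cl)c(Cl)c2)oc1Cl` gives 3.95 nM. On these numbers compound 3 holds the lowest value, with compound 1 nearest, within the scatter, and compound 2 furthest, beyond it. Going by the values given here, the single step at the saturated chain carbon bound to a saturated ring carbon, a 1.1-fold lower number from compound 1 to compound 3 (0.05 log units; within the scatter), left the number essentially unchanged.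

Compound 4 `Cn1ncc(Cl)c1-c1cc(C(=O)N[C@@H]2CN[C@H](CC(=O)O)C[C@H]2c2ccc(Cl)c(Cl)c2)oc1Cl` differs from compound 3 at the carbonyl carbon of that chain. hydroxy in place of cyclopropylamino on a carbonyl carbon

Among the compounds with values here, no measured step exchanges a carbamoyl for a carboxy group, so the only step bearing on this change is the within-scatter one at the same chain position, and it carries no direct information on the loss of the cyclopropylamino group. A modest rise in the number is expected for compound 4, as the step of a 3.0-fold higher number from compound 3 to compound 4 (0.48 log units; beyond the scatter). Compound 4 is therefore estimated at 12 nM, within a range from 3.5 nM to 45 nM.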

Compound 4, half-maximal inhibitory concentration: 1.94 nM
Compound 4: the middle estimate sits 6.2-fold (0.79 log units) above what was measured; measured number outside the range, below it.
By their numbers in this assay, from the lowest: compound 4; then compounds 3 and 1 (each within the scatter of the next); then compound 2.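

Going by these compounds alone, with the cyclopropylamino group on the carbonyl carbon exchanged for hydroxy, this assay shows a 2.0-fold lower number from compound 3 to compound 4 (0.31 log units; beyond the scatter) and the first step at this chain to lie beyond the scatter, so this chain position is not silent to every change. Set against the (1H-1,2,4-triazol-1-yl)methyl group, carboxy gives a 2.3-fold lower number from compound 1 to compound 4 (0.36 log units; beyond the scatter) as well, whereas the earlier exchange of that group for cyclopropylcarbamoyl gave a 1.1-fold lower number from compound 1 to compound 3 (0.05 log units; within the scatter) and stayed within the scatter. The three-membered ring is therefore not needed to keep the number low in this pair, and nothing available explains the drop.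

The compounds shown leave open how a methyl ester or an unsubstituted carboxamide would read on the same carbonyl carbon. They also leave open whether a carboxylic acid on a longer chain would keep the number where compound 4 stands.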